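The compounds below may be only part of what the source reports. "The series", "measured", "known", "first", "only" and "open" are said of these compounds alone.

Working notes on the series. Compound 1 `COc1cc(N)c(Cl)cc1NC(=O)C1CCN(CC2CC2)CC1` carries cyclopropyl on a saturated chain carbon bound to an amine nitrogen in a ring. In a functional assay on the whole organism for antagonist activity, with Mus musculus as the target (a lower number here means that less compound is needed, a higher number that more compound is needed for the effect), compound 1 gives only a limit, > 10 mg/kg. Compound 2 `COc1cc(N)c(Cl)cc1NC(=O)C1CCN(Cc2ccccc2Cl)CC1` carries 2-chlorophenyl at the same place. In this assay compound 2 also gives only a limit, > 4 mg/kg. The step that the two limits leave unreadable from compound 1 to compound 2 is therefore not readable; the two limits the limit of > 10 mg/kg in this assay, at which 1 of the 2 values shown sits, and the limit of > 4 mg/kg in this assay, at which 1 of the 2 values shown sits, do not settle whether compound 2 stands higher or lower than compound 1. Where compound 2 stands is known only as a limit.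

Compound 3 `CCCCCN1CCC(C(=O)Nc2cc(Cl)c(N)cc2OC)CC1` follows from compound 2 by butyl in place of 2-chlorophenyl on a saturated chain carbon bound to an amine nitrogen in a ring, which cut one bond further out reads 2-chlorobenzyl to pentyl. Going by the values given here, no measured step bears on this change; the only step is unreadable, and both measured compounds sit at limits. The expectation for compound 3 can rest only on the fact that a small group at this place in compound 1 gave > 10 mg/kg, a limit. The step that the limit leaves unreadable from compound 2 to compound 3 is accordingly expected to be small, if any. Compound 3 is thus estimated to give about 10 mg/kg in this assay, within 3 mg/kg to 30 mg/kg.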

Compound 3, dose for half-maximal effect: > 10 mg/kg
Compound 3: only a limit was reported; the forecaster's own chance of this, stated with the estimate: 70%; the middle value sits exactly at the limit.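

Compound 3 gives > 10 mg/kg in this assay, which is only a limit, so neither the step to it from compound 1 nor the step from compound 2 can be read. The compounds shown leave open where any of the three actually stands in this assay, and whether cyclopropyl, 2-chlorophenyl or butyl at this place makes any difference.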